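Carboxy to Amino(carboxy)methyl on a Shared Core

The source may report more compounds than this note shows. Statements on the series, on what has been measured and on what is new or still open speak of the compounds shown alone.

The measured compounds:
compound 1, `COc1cc2c(cc1O)CCC(C)(CC(=O)O)O2`, gives 53.1%
compound 2, `COc1cc2c(cc1O)CCC(C)(CC(=O)N[C@H](C(=O)O)C(C)C)O2`, gives 61%
compound 3, `COc1cc2c(cc1O)CCC(C)(CC(=O)N[C@@H](CCC(N)=O)C(=O)O)O2`, gives 58.2%

These three were read in an ADME assay on SH-SY5Y cells (Homo sapiens) for cytotoxicity, read by MTT assay, with a stated time of 24 h, tested at 100 uM; a higher number here means a weaker effect of the compound at the concentration tested, a lower number a stronger effect. Compound 1 gives the lowest of the three numbers, but its nearest neighbour compound 3 and its furthest neighbour compound 2 both lie within the usual scatter of it, so no order among them can be claimed. The step of a number 7.9 percentage points higher from compound 1 to compound 2 (within the scatter) and the step of a number 2.8 percentage points lower from compound 2 to compound 3 (within the scatter) were both within the scatter.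

Compound 4, `COc1cc2c(cc1O)CCC(C)(CC(N)C(=O)O)O2`, differs from compound 1 in one place: amino(carboxy)methyl in place of carboxy on a saturated chain carbon bound to a saturated ring carbon. Neither measured step touches this place; both changed the group on the carbonyl carbon, whereas here the carboxy on a saturated chain carbon bound to a saturated ring carbon is replaced by amino(carboxy)methyl. What the measured steps do show is that altering the acid end of compound 1 left this assay unmoved, and compound 4 is expected to behave the same way, with a step of a number 3.9 percentage points higher from compound 1 to compound 4 (within the scatter) that stays within the scatter. Compound 4 is therefore estimated at 57%, with a range from 45% to 69%.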

Compound 4, a percentage reported as activity, at one concentration (the size of the read-out at that concentration, not a potency): 60.1%
For compound 4 the middle estimate is 3.1 percentage points below the measured one, and the stated range covers the measured number.
By their numbers in this assay, from the lowest: compounds 1, 3, 4 and 2 (each within the scatter of the next).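

In this assay, the replacement of carboxy by amino(carboxy)methyl on a saturated chain carbon bound to a saturated ring carbon gives a number 7 percentage points higher from compound 1 to compound 4 (within the scatter), so a change at this place has now been read, and it stays within the scatter. Unlike the earlier steps, which changed only the group on a carbonyl carbon, this one turns carboxymethyl into 2-amino-2-carboxyethyl, adding an amine while keeping a carboxylic acid, and even this change to the chain itself gives no difference that can be claimed. Nothing available on these compounds bears on why the read-out holds steady across this change.

The compounds shown leave open whether an amine at this place without the carboxylic acid, or a methyl ester in place of that acid, would also stay within the scatter of compound 1. They also leave open whether a longer chain carrying the same amino and carboxy groups, or a methyl ether in place of the hydroxy on the shared core, would read any differently.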